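Smaller group on the ring nitrogen, chlorine kept on the benzyl

A few compounds are considered here, and "the series" means these few. Any claim that something is new, unique, unknown or untested is made for them only; others in the source may bear on it.

Compound 2, `CC(C)(C)n1nc(Cc2ccc(Cl)cc2)c2ccccc2c1=O`, carries a tert-butyl on the ring nitrogen and a chlorine on its benzyl ring. In a functional assay on aorta with Alpha-1D adrenergic receptor (Rattus norvegicus) as the target (a higher number here means that more compound is needed for the effect, a lower number that less compound is needed), compound 2 reaches only a limit of the assay, > 100000 nM, not a number. Compound 1, `Cn1nc(Cc2ccccc2)c2ccccc2c1=O`, with methyl on that nitrogen and a plain benzyl, also gives a limit in this assay, <= 10000 nM. Compound 3, `Cn1nc(Cc2ccc(Cl)cc2)c2ccccc2c1=O`, has not been measured; it differs from compound 2 by methyl in place of tert-butyl on an aromatic nitrogen. Given where compound 1 sits, the step from compound 2 to compound 3 is expected to be a large drop in this assay, an at least 20-fold lower number from compound 2 to compound 3 (1.30 log units; beyond the scatter). Compound 3 is expected to give about 5000 nM, between 1000 nM and 30000 nM.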

Compound 3, half-maximal effective concentration: 430 nM
Estimate against measurement, compound 3: 12-fold (1.07 log units) above, and the stated range ends above it.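

In this assay, methyl in place of tert-butyl on the aromatic nitrogen gives an at least 230-fold lower number from compound 2 to compound 3 (2.36 log units; beyond the scatter), so the group on this ring nitrogen can change the result greatly. Compound 3 is also the only compound of the three shown with a number rather than a limit. The step from compound 1 to compound 3, chloro in place of hydrogen, cannot be read, because compound 1 stands at a limit: the limit of <= 10000 nM in this assay, at which 1 of the 3 values shown sits.

As far as these compounds go, whether ethyl or isopropyl on the ring nitrogen would fall closer to compound 3 or to compound 2 remains open. So does the outcome of an amine or a carboxylic acid in place of chlorine on the benzyl ring.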